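The source may report more compounds than this note shows. Statements on the series, on what has been measured and on what is new or still open speak of the compounds shown alone.

Measured compounds in an ADME assay on the whole organism (Macaca fascicularis) for metabolic stability, read by LC-MS, using cassette dosing, at a dose of 1 mg/kg by the oral route; a lower number here means that the compound disappears faster, a higher number that the compound lasts longer:
- compound 1 `Cc1ccc(-c2nc(=O)o[nH]2)c(-c2ccc([C@@H](C)N(CC3CC3)c3nc4c(C(=O)O)cccc4o3)cc2)c1` gives 2.8 h
- compound 2 `CCCCN(c1nc2c(NC(C)=O)cccc2o1)[C@H](C)c1ccc(-c2ccccc2-c2nnn[nH]2)cc1` gives 2.2 h
- compound 3 `C[C@H](c1ccc(-c2ccccc2-c2nc(=O)o[nH]2)cc1)N(CC1CC1)c1nc2c(C(=O)O)cccc2o1` gives 2.6 h

The three half-lives of compound 1, compound 2 and compound 3 all lie within the usual scatter of one another, so compound 2 cannot be set apart from the other two on these numbers alone. The unmeasured compound 4 `CCCCN(c1nc2ccccc2o1)[C@H](C)c1ccc(-c2ccccc2-c2nnn[nH]2)cc1` differs from compound 2 in one place: hydrogen in place of acetamido on an aromatic carbon. Within the data shown here, only one measured step is available in this assay, a 1.1-fold lower number from compound 1 to compound 3 (0.03 log units; within the scatter), and it concerns a different change in a different part of the structure, a hydrogen in place of a methyl; it bears on the present step only in showing that a small change on an aromatic carbon of this series left the half-life unmoved. Among the measured compounds shown here, no measured step removes an acetamido. The expected step of no change at the digits printed from compound 2 to compound 4 (within the scatter) is therefore none beyond the scatter, with a wide range to reflect the missing precedent. Compound 4 is expected to give 2.2 h in this assay, between 1 h and 4.8 h.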

Compound 4, half-life: 3.2 h
Estimate against measurement, compound 4: 1.5-fold (0.16 log units) below, and the stated range covers the measured number.
By their numbers in this assay, from the lowest: compounds 2, 3, 1 and 4 (each within the scatter of the next).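

In this assay, hydrogen in place of acetamido on an aromatic carbon of the six-membered ring of the shared core gives a 1.5-fold higher number from compound 2 to compound 4 (0.16 log units; within the scatter). Among these compounds, this is the first step at this position, and it shows that, with the butyl chain and the tetrazole held constant, the half-life with the acetamido cannot be told apart from the half-life without it. No measurement bearing on the reason for this outcome is available. The compounds shown leave open whether an amine, a methoxy group or a longer amide chain on this same carbon would also leave the half-life within the scatter. They also leave open whether the acetamido would behave in the same way on a core carrying the cyclopropylmethyl group in place of the butyl chain.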